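The source may report more compounds than this note shows. Statements on the series, on what has been measured and on what is new or still open speak of the compounds shown alone.

Compound 1 `CC(=O)Nc1c(C(O)(C(F)(F)F)C(F)(F)F)ccc2ccccc12`: 18 nM
Compound 2 `COc1cccc(C(=O)Nc2c(C(O)(C(F)(F)F)C(F)(F)F)ccc3ccccc23)c1`: 185 nM

In an assay on LtK cells with ATP-sensitive inward rectifier potassium channel 11 (Homo sapiens) as the target (on this read-out lower numbers stand for an effect already at smaller amounts and higher numbers for an effect only at larger amounts of compound), compound 2 holds the higher of the two numbers, and its nearest neighbour is compound 1. Compound 3 `O=C(Nc1c(C(O)(C(F)(F)F)C(F)(F)F)ccc2ccccc12)c1ccc(I)cc1` has not yet been measured; it differs from compound 2 by 4-iodophenyl in place of 3-methoxyphenyl on a carbonyl carbon. Within the data shown here, the only measured step, a 10-fold higher number from compound 1 to compound 2 (1.01 log units; beyond the scatter), exchanges the whole group on the carbonyl carbon and so does not bear on swapping one aryl group for another. Among the measured compounds shown here, no measured step therefore guides the expectation, and compound 3 is expected to stay close to compound 2, with a 1.2-fold lower number from compound 2 to compound 3 (0.09 log units; within the scatter) not beyond the scatter. Compound 3 is estimated at 150 nM, within a range of 50 nM to 600 nM.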

Compound 3, half-maximal effective concentration: 154 nM
Compound 3: the middle estimate sits 1.0-fold (0.01 log units) below what was measured; the range from low to high includes it.
By their numbers in this assay, from the lowest: compound 1; then compounds 3 and 2 (each within the scatter of the next).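

In this assay, the step of a 1.2-fold lower number from compound 2 to compound 3 (0.08 log units; within the scatter) shows that, on this carbonyl carbon, 4-iodophenyl and 3-methoxyphenyl cannot be told apart. The step of an 8.6-fold higher number from compound 1 to compound 3 (0.93 log units; beyond the scatter) shows that a second aryl group also stands well apart from the methyl of compound 1, so the gap is not particular to 3-methoxyphenyl. Nothing at hand explains this result.

Still open, as far as these compounds go, is whether an ethyl group or a longer chain on this carbonyl carbon stays near compound 1 at 18 nM or moves towards the aryl compounds. Also open, from the compounds shown here alone, is how a phenyl ring carrying an amine or a carboxylic acid would behave here.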